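Aryl urea series: methyl to methylsulfanyl step

The source may report more compounds than this note shows. Statements on the series, on what has been measured and on what is new or still open speak of the compounds shown alone.

Measured compounds:
compound 1 `O=C(Nc1cccc(Br)c1)N[C@H]1CC[C@H](Oc2ccc(F)cc2)CC1`: 6200 nM
compound 2 `Cc1cccc(NC(=O)N[C@H]2CC[C@H](Oc3ccc(F)cc3)CC2)c1`: 14400 nM

In a functional assay on CRL2813 cells (Homo sapiens) for cytotoxicity, read by sulforhodamine B assay, with a stated time of 5 days (on this read-out higher numbers stand for weaker inhibition and lower numbers for stronger inhibition), compound 2 stands at the higher of the two numbers measured, compound 1 giving the lower. Compound 3 `CSc1cccc(NC(=O)N[C@H]2CC[C@H](Oc3ccc(F)cc3)CC2)c1` differs from compound 2 in one place: methylsulfanyl in place of methyl on an aromatic carbon. Going by the values given here, the only step on record, a 2.3-fold higher number from compound 1 to compound 2 (0.37 log units; beyond the scatter), concerns a different exchange on the same aromatic carbon and offers no direct precedent for methylsulfanyl; it shows only that exchanges here have so far moved the number modestly. For compound 3 the expected step is a 1.4-fold lower number from compound 2 to compound 3 (0.16 log units; within the scatter), within or just beyond the scatter. Compound 3 is estimated at 10000 nM, with a range of 4000 nM to 30000 nM.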

Compound 3, half-maximal inhibitory concentration: 11100 nM
For compound 3 the middle estimate is 1.1-fold (0.05 log units) below the measured one; measured number inside the range.
By their numbers in this assay, from the lowest: compounds 1, 3 and 2 (each within the scatter of the next, the first and the last beyond it).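

In this assay, methylsulfanyl on this aromatic carbon does not separate from methyl, with a 1.3-fold lower number from compound 2 to compound 3 (0.11 log units; within the scatter), or from bromo, with a 1.8-fold higher number from compound 1 to compound 3 (0.25 log units; within the scatter). Compound 3 therefore falls within the scatter of both other compounds, even though a 2.3-fold higher number from compound 1 to compound 2 (0.37 log units; beyond the scatter) lies beyond it, so this exchange gives no clear shift at this position. No evidence on hand accounts for these numbers. Going by these compounds, whether an amine, a carboxylic acid or a longer chain on the same carbon would move the number well outside this narrow band remains open.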